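Adding a hexyloxy group to compound 3

The compounds below may be only part of what the source reports. "The series", "measured", "known", "first", "only" and "open" are said of these compounds alone.

In a functional assay on cells (Endothelial cell) for inhibition (on this read-out lower numbers stand for stronger inhibition and higher numbers for weaker inhibition), compound 3 `CC(C)(C)c1cc(-c2cc(=O)c3ccccc3o2)cc(C(C)(C)C)c1O` gives 2500 nM, the highest number among the three compounds measured. Compound 1 `CC(C)(C)c1cc(-c2cc(=O)c3ccc(OCC(=O)O)cc3o2)cc(C(C)(C)C)c1O` gives 500 nM, and compound 2 `CCOC(=O)C(C)(C)Oc1ccc2c(=O)cc(-c3cc(C(C)(C)C)c(O)c(C(C)(C)C)c3)oc2c1` gives 500 nM. These last two do not separate, with no change at the digits printed from compound 1 to compound 2 (within the scatter).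

Compound 4 `CCCCCCOc1ccc2c(=O)cc(-c3cc(C(C)(C)C)c(O)c(C(C)(C)C)c3)oc2c1` differs from compound 3 by hexyloxy in place of hydrogen on an aromatic carbon, with hexyloxy in place of hydrogen on an aromatic carbon. The closest evidence comes from the two measured steps that swap an oxygen-linked group for hydrogen on an aromatic carbon. These are a 5.0-fold higher number from compound 1 to compound 3 (0.70 log units; beyond the scatter) and a 5.0-fold higher number from compound 2 to compound 3 (0.70 log units; beyond the scatter). Read backwards, both suggest that adding such a group to compound 3 brings the number down by a modest amount. Both groups carry an ester or acid end, however, and hexyloxy has none, so the data do not show whether a plain chain behaves alike. A modest step towards stronger inhibition is therefore expected, and the expected step is a 3.6-fold lower number from compound 3 to compound 4 (0.55 log units; beyond the scatter). Compound 4 is estimated at 700 nM, with an expected range of 250 nM to 2500 nM.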

Compound 4, half-maximal inhibitory concentration: 50000 nM
Beside the measured number, compound 4's estimate is 71-fold (1.85 log units) below it; measured number outside the range, above it.
By their numbers in this assay, from the lowest: compounds 1 and 2 (each within the scatter of the next); then compound 3; then compound 4.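

In this assay, an oxygen-linked group on this aromatic carbon, para to a fused ring, does not by itself lower the number: hexyloxy in place of hydrogen gives a 20-fold higher number from compound 3 to compound 4 (1.30 log units; beyond the scatter). This is the opposite direction to the steps from compound 3 to the two compounds whose groups end in an acid or ester, and the comparisons with those compounds are a 100-fold higher number from compound 2 to compound 4 (2.00 log units; beyond the scatter) and a 100-fold higher number from compound 1 to compound 4 (2.00 log units; beyond the scatter). The direction of the change at this position therefore depends on what the oxygen carries, and nothing available explains this reversal.

The compounds shown leave open how the number changes with chain length, since a short methoxy group could fall on either side of hydrogen. They also leave open whether an amine or a hydroxyl at the end of the hexyl chain would bring the number back down.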